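The source may report more compounds than this note shows. Statements on the series, on what has been measured and on what is new or still open speak of the compounds shown alone.

Measured so far in an assay on CHO cells for inhibition of metabotropic glutamate receptor 1 (Rattus norvegicus); on this read-out higher numbers stand for weaker inhibition and lower numbers for stronger inhibition:
- compound 1 `CCCOC(=O)c1[nH]c(CO)c(C(=O)OC(C)(C)C)c1C`, 7900 nM
- compound 2 `CCCOC(=O)c1[nH]cc(C(=O)OC(C)C(C)(C)C)c1C`, 4 nM
- compound 3 `Cc1c(C(=O)OC(C)(C)C)c[nH]c1C(=O)Sc1ccccn1`, 3000 nM

Compound 1 gives the highest number of the three, so it is the weakest inhibitor of the set. Its nearest neighbour on the read-out is compound 3, whose number is lower by more than the scatter, and furthest away is compound 2, whose number is lower by a very wide margin. Within the data shown here, no two of these three differ in one place only, so no single-point step between measured compounds is available here, and the three values can only be read side by side.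

The next compound, compound 4 `CCCOC(=O)c1[nH]c(C(=O)NCC2CC2)c(C(=O)OC(C)(C)C)c1C`, differs from compound 1 in one place: (cyclopropylmethyl)carbamoyl in place of hydroxymethyl on an aromatic carbon. The change keeps one hydrogen-bond donor and one hydrogen-bond acceptor at that position but brings in a considerably larger group with a three-membered ring. Nothing in the measured set tests this group, so the size of the step is open. On balance, a modest move toward a lower number is expected, the step from compound 1 to compound 4 being estimated at a 4.0-fold lower number from compound 1 to compound 4 (0.60 log units; beyond the scatter) in this assay, with the uncertainty wide in both directions. Compound 4 is therefore expected to reach about 2000 nM, within 300 nM to 15000 nM.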

Compound 4, half-maximal inhibitory concentration: 2500 nM
Estimate against measurement, compound 4: 1.3-fold (0.10 log units) below; the range from low to high includes it.
By their numbers in this assay, from the lowest: compound 2; then compounds 4 and 3 (each within the scatter of the next); then compound 1.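

In this assay, the aromatic carbon next to the ring nitrogen and next to the ring atom that bears a tert-butoxycarbonyl group now has its first single-point step: (cyclopropylmethyl)carbamoyl in place of hydroxymethyl gives a 3.2-fold lower number from compound 1 to compound 4 (0.50 log units; beyond the scatter). This position therefore accepts a much larger group with a three-membered ring, while the hydrogen-bond donor and acceptor counts stay the same, and the number falls rather than rises, though compound 4 still stands at 2500 nM. No supporting data bear on why the number moves with this change.

Among these compounds, with only this one pair, the step cannot be assigned to the amide link, to the cyclopropylmethyl part, or to the two together. A primary carboxamide, a carboxylic acid, an aminomethyl group or a longer straight-chain amide at this same position, on the core of compound 1, would show which of these parts tracks the read-out and whether the modest step can grow in either direction.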